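Coumarin triazole series: chloroalkyl chain to piperazine dithiocarbamate

The source may hold more compounds than are shown below. What is called first, only, known or untested is meant among the compounds shown, and "the series" means these compounds.

Compound 1 `O=c1cc(Cn2cc(CCCCl)nn2)c2ccc(O)cc2o1` returns only a limit in a functional assay on HepG2 cells (Homo sapiens) for inhibition, read by MTT assay, with a stated time of 72 h (on this read-out lower numbers stand for stronger inhibition and higher numbers for weaker inhibition), namely > 100000 nM. It therefore stands at the limit of > 100000 nM in this assay, at which 1 of the 3 values shown sits, and its place relative to the others is undetermined. Compound 2 `CCCCCCc1ccc(-c2cn(Cc3cc(=O)oc4cc(O)ccc34)nn2)cc1` gives 9160 nM in this assay, and compound 3 `O=c1cc(Cn2cc(CNS(=O)(=O)c3ccc(F)cc3Cl)nn2)c2ccc(O)cc2o1` gives 74800 nM in this assay, both within the measured range.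

Compound 4 `O=c1cc(Cn2cc(CSC(=S)N3CCNCC3)nn2)c2ccc(O)cc2o1` differs from compound 1 by a group of 9 heavy atoms (5 carbon, 2 nitrogen, 2 sulfur; one six-membered non-aromatic ring with 2 hetero atoms) in place of a group of 3 heavy atoms (2 carbon, 1 chlorine; no ring), on a saturated chain carbon bound to an aromatic carbon. Within the data shown here, no measured pair covers this kind of change, so the expectation rests on compounds 2 and 3, where the larger chain ends come with measured numbers rather than limits. A step down from the limit, an at least 3.3-fold lower number from compound 1 to compound 4 (0.52 log units; beyond the scatter), is expected. For compound 4 the expected value is 30000 nM, with a range from 8000 nM to 100000 nM.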

Compound 4, half-maximal inhibitory concentration: > 100000 nM
Compound 4: no number, only a limit (the forecaster's own chance of this, stated with the estimate: 25%); middle value at least 3.3-fold (0.52 log units) away from the limit.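

Compound 1 and compound 4 both return only limits, so no step can be read between them: the limit of > 100000 nM in this assay, at which 2 of the 4 values shown sit.

Still open, as far as these compounds go, is whether exchanging the 2-chloroethyl group for the larger ring-bearing group changes the number in this assay at all.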